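Replacing the Nitro-Bearing Ring on the Sulfonyl Sulfur

A few compounds are considered here, and "the series" means these few. Any claim that something is new, unique, unknown or untested is made for them only; others in the source may bear on it.

Of the compounds shown here, three sharing one core have been measured in a functional assay on K562 cells (Homo sapiens) for inhibition, read by trypan blue exclusion, with a stated time of 72 h; a lower number here means a stronger inhibitor, a higher number a weaker inhibitor. Compound 3 `Cn1c(=O)c(S(=O)(=O)c2ccc([N+](=O)[O-])cc2F)cc2cnc(Nc3ccc4[nH]ccc4c3)nc21` gives 200 nM, the lowest number of the three. Compound 1 `Cn1c(=O)c(S(=O)(=O)c2ccc(F)cc2[N+](=O)[O-])cc2cnc(Nc3ccc4[nH]ccc4c3)nc21` gives 900 nM, and the step of a 4.5-fold lower number from compound 1 to compound 3 (0.65 log units; beyond the scatter) shows that exchanging 4-fluoro-2-nitrophenyl for 2-fluoro-4-nitrophenyl on the sulfonyl sulfur lowers the number modestly. Compound 2 `Cn1c(=O)c(S(=O)(=O)c2ccc(F)cc2)cc2cnc(Nc3ccc4occc4c3)nc21` differs from compound 3 in two places. In this assay compound 2 gives 5000 nM.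

Compound 4 `Cc1ccc(S(=O)(=O)c2cc3cnc(Nc4ccc5[nH]ccc5c4)nc3n(C)c2=O)cc1` has not been measured. It differs from compound 3 as follows: 4-methylphenyl in place of 2-fluoro-4-nitrophenyl on a sulfonyl sulfur. The incoming group keeps a single carbon ring but carries neither the nitro group nor the fluorine. Among the measured compounds shown here, no measured step removes only one of these two groups, so no single step bears directly on this change. For the measured compounds named here, the one relevant step, a 4.5-fold lower number from compound 1 to compound 3 (0.65 log units; beyond the scatter), shows that merely rearranging the two substituents already shifts the number beyond the scatter, so removing both is expected to matter at least as much. Compound 2, which also lacks the nitro group, gives a far higher number than compound 3, although its second change blurs that reading.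

Compound 4 is therefore expected to give a higher number than compound 3, by a 7.5-fold higher number from compound 3 to compound 4 (0.88 log units; beyond the scatter). The estimate for compound 4 is 1500 nM, with a range from 400 nM to 6000 nM.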

Compound 4, half-maximal inhibitory concentration: 750 nM
For compound 4 the middle estimate is 2.0-fold (0.30 log units) above the measured one; the measured number falls inside the stated range.
By their numbers in this assay, from the lowest: compound 3; then compounds 4 and 1 (each within the scatter of the next); then compound 2.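

In this assay, 4-methylphenyl in place of 2-fluoro-4-nitrophenyl on the sulfonyl sulfur gives a 3.8-fold higher number from compound 3 to compound 4 (0.57 log units; beyond the scatter), so a ring with neither the nitro group nor the fluorine costs only a modest rise in the number. The second comparison, a 1.2-fold lower number from compound 1 to compound 4 (0.08 log units; within the scatter), puts the 4-methylphenyl ring of compound 4 level with the 4-fluoro-2-nitrophenyl ring of compound 1, so carrying a nitro group and a fluorine does not by itself give a lower number here, and of these three rings only the 2-fluoro-4-nitrophenyl ring of compound 3 stands apart. Nothing measured alongside these numbers speaks to why the rings differ.

On these data alone, it remains open which of the two groups in compound 3 matters more, since neither a 4-nitrophenyl nor a 2-fluorophenyl ring appears on the shared core with the rest of compound 3 unchanged. The compounds shown also do not tell how a ring bearing an amine or a carboxylic acid would behave on the sulfonyl sulfur, or whether a plain methyl group could stand in for the ring altogether.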